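A few compounds are considered here, and "the series" means these few. Any claim that something is new, unique, unknown or untested is made for them only; others in the source may bear on it.

- compound 1 `CNC(=O)C[C@@H]1C[C@@H](c2ccc(Cl)c(Cl)c2)[C@H](NC(=O)c2cc(-c3c(Cl)cnn3C)c(Cl)o2)CN1`: 450 nM
- compound 2 `Cn1ncc(Cl)c1-c1cc(C(=O)N[C@@H]2CN[C@H](CCN3CCCCC3)C[C@H]2c2ccc(Cl)c(Cl)c2)oc1Cl`: 1020 nM
- compound 3 `Cn1ncc(Cl)c1-c1cc(C(=O)N[C@@H]2CN[C@H](CCO)C[C@H]2c2ccc(Cl)c(Cl)c2)oc1Cl`: 340 nM

These values come from a functional assay on HCT-116 cells (Homo sapiens) for antiproliferative activity, read by sulforhodamine B assay, with a stated time of 72 h; on this read-out lower numbers stand for stronger inhibition and higher numbers for weaker inhibition. Compound 3 gives 340 nM, which places it in the lower part of this small set. The data show a 1.3-fold lower number from compound 1 to compound 3 (0.12 log units; within the scatter), and also a 3.0-fold lower number from compound 2 to compound 3 (0.48 log units; beyond the scatter).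

The next compound to be measured is compound 4 `Cn1ncc(Cl)c1-c1cc(C(=O)N[C@@H]2CN[C@H](CC(=O)NC3CCC3)C[C@H]2c2ccc(Cl)c(Cl)c2)oc1Cl`. It differs from compound 3 as follows: cyclobutylcarbamoyl in place of hydroxymethyl on a saturated chain carbon bound to a saturated ring carbon. In words, this is cyclobutylcarbamoyl in place of hydroxymethyl on a saturated chain carbon bound to a saturated ring carbon.

The closest guide is compound 1, at 450 nM, which carries methylcarbamoyl at that same place. Among the measured compounds shown here, compound 4 keeps the carbamoyl but bears a cyclobutyl group instead of the methyl, and no measured compound shows what that swap does. For the measured compounds named here, the one step here that exchanges a carbamoyl for hydroxymethyl is a 1.3-fold lower number from compound 1 to compound 3 (0.12 log units; within the scatter). The piperidin-1-yl group behind a 2.3-fold higher number from compound 1 to compound 2 (0.36 log units; beyond the scatter) is absent from compound 4, so that step offers only a rough sense of how far this chain can move the number.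

No step beyond the scatter is therefore expected, and the estimated change is a 1.3-fold higher number from compound 3 to compound 4 (0.12 log units; within the scatter). For compound 4 the expected value is 450 nM, with an estimated range from 200 nM to 1000 nM.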

Compound 4, half-maximal inhibitory concentration: 430 nM
Compound 4: the middle estimate sits 1.0-fold (0.02 log units) above what was measured; measured number inside the range.
By their numbers in this assay, from the lowest: compounds 3, 4 and 1 (each within the scatter of the next); then compound 2.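

In this assay, swapping methyl for cyclobutyl on the amide-type nitrogen stays within the scatter (a 1.0-fold lower number from compound 1 to compound 4 (0.02 log units; within the scatter)), so this nitrogen accepts a four-membered carbon ring as well as a single methyl without a measurable shift in the number. Cyclobutylcarbamoyl and hydroxymethyl also cannot be told apart at this position (a 1.3-fold higher number from compound 3 to compound 4 (0.10 log units; within the scatter)), whereas the step from the piperidine-bearing compound is beyond the scatter (a 2.4-fold lower number from compound 2 to compound 4 (0.38 log units; beyond the scatter)), which leaves compound 2 as the only one of the four whose number stands clear of the others. Nothing available here explains why these groups read alike or why compound 2 stands apart.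

Still open, going by these compounds, is how large the group on the amide-type nitrogen can become, as a cyclohexyl or phenyl group there would test the limit of what this position accepts. It is also unclear whether the higher number of compound 2 follows the amine nitrogen or the ring as a whole, which a cyclohexyl ring on the same chain or a carboxylic acid at this position could help to separate.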